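Hydroxyphenyl Ketone Replacing the Naphthyl Ketone

The source may report more compounds than this note shows. Statements on the series, on what has been measured and on what is new or still open speak of the compounds shown alone.

Compound 2 `COc1cc(-c2nnc3n2NC(c2ccco2)C(C(=O)c2cccc4ccccc24)S3)cc(OC)c1OC` stands at the edge of what was measured: in a functional assay on A549 cells (Homo sapiens) for cytotoxicity, read by MTT assay, with a stated time of 48 h (on this read-out lower numbers stand for stronger inhibition and higher numbers for weaker inhibition), compound 2 reached only the limit of > 100000 nM, not a number. Its companion, compound 1 `COc1cc(-c2nnc3n2NC(c2ccco2)C(C(=O)c2ccccc2C)S3)cc(OC)c1OC`, in this assay gives 80000 nM. Among the compounds with values here, the single measured step, an at least 1.2-fold higher number from compound 1 to compound 2 (0.09 log units; that floor lies within the scatter), exchanged 2-methylphenyl for naphthalen-1-yl on a carbonyl carbon and ends at the limit of > 100000 nM in this assay, at which 1 of the 2 values shown sits. Compound 3 `COc1cc(-c2nnc3n2NC(c2ccco2)C(C(=O)c2ccc(O)cc2)S3)cc(OC)c1OC` differs from compound 2 by 4-hydroxyphenyl in place of naphthalen-1-yl on a carbonyl carbon. Within the data shown here, only that one step bears on this change, and since it ends at a limit it fixes no size, so no step beyond the scatter is expected in either direction. Compound 3 is therefore estimated to give about 100000 nM, in the range 40000 nM to 250000 nM, which would be an expected step of a number no higher from compound 2 to compound 3 (the limit leaves the size open) in this assay.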

Compound 3, half-maximal inhibitory concentration: 93400 nM
Estimate against measurement, compound 3: 1.1-fold (0.03 log units) above, and the stated range covers the measured number.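

Putting 4-hydroxyphenyl in place of 2-methylphenyl on a carbonyl carbon gives a 1.2-fold higher number from compound 1 to compound 3 (0.07 log units; within the scatter), so a hydrogen-bond donor and acceptor entering at this place bring no step beyond the scatter in this assay. Putting 4-hydroxyphenyl in place of naphthalen-1-yl, with one six-membered aromatic ring instead of two, gives an at least 1.0-fold lower number from compound 2 to compound 3 (0.02 log units; that floor lies within the scatter), and that figure is only a floor. Compound 2 is held at a limit and not a number, so the size of this step stays open: the limit of > 100000 nM in this assay, at which 1 of the 3 values shown sits.

The compounds shown leave open whether an amine or a carboxylic acid in place of the hydroxyl on the phenyl ring would move the number in this assay. They also leave open whether any group on this carbonyl carbon can give a step beyond the scatter.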